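Chloro to dimethylamino: working notes on compound 4

A few compounds are considered here, and "the series" means these few. Any claim that something is new, unique, unknown or untested is made for them only; others in the source may bear on it.

Measured in a functional assay on CCRF-CEM cells (Homo sapiens) for inhibition; a lower number here means a stronger inhibitor, a higher number a weaker inhibitor:
- compound 1 `O=C1/C(=C/c2cccc(F)c2)CCc2ccccc21`: 8010 nM
- compound 2 `CN(C)c1ccc(/C=C2\CCc3ccccc3C2=O)cc1`: 1650 nM
- compound 3 `O=C1/C(=C/c2ccc(Cl)cc2)CCCc2ccccc21`: 15100 nM

Compound 3 gives 15100 nM. Compound 1 gives 8010 nM. These two numbers lie within the scatter of each other. Compared with compound 3, the lower number belongs to compound 2 at 1650 nM. That gap to compound 3 lies beyond the scatter.

Compound 4 `CN(C)c1ccc(/C=C2\CCCc3ccccc3C2=O)cc1` keeps the core of compound 3 and has not yet been measured. The change is dimethylamino in place of chloro on an aromatic carbon, para to a large group.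

For the measured compounds named here, no measured pair isolates this change. Going by the values given here, compound 2 is the only measured compound with dimethylamino, and its core differs from that of compound 3, so it offers only indirect guidance. With compound 2 at 1650 nM, a step to a lower number in this assay, beyond the scatter, is expected. The expected step is a 4.6-fold lower number from compound 3 to compound 4 (0.66 log units; beyond the scatter). For compound 4 the estimated value is 3300 nM, with an expected range of 1100 nM to 9000 nM.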

Compound 4, half-maximal inhibitory concentration: 3050 nM
Compound 4: middle estimate off by 1.1-fold (0.03 log units), on the high side; measured number inside the range.
By their numbers in this assay, from the lowest: compounds 2 and 4 (each within the scatter of the next); then compounds 1 and 3 (each within the scatter of the next).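

In this assay the change now has a direct reading on the core of compound 3: dimethylamino in place of chloro on an aromatic carbon, para to a large group, gives a 5.0-fold lower number from compound 3 to compound 4 (0.69 log units; beyond the scatter) on this single pair. For the compounds shown here, until this pair, dimethylamino had been seen only on the different core of compound 2, so the result is the first evidence that this position responds to this change with the core held fixed. Nothing measured on these compounds accounts for the step.

Open, on these data alone, is whether methoxy, a primary amine or morpholine on the same aromatic carbon would give a step of similar size. Also open, as far as these compounds go, is whether the same exchange of chloro for dimethylamino would carry over to the core of compound 2.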